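Sulfonyl ester in place of the aromatic hydroxy hydrogen

The source may hold more compounds than are shown below. What is called first, only, known or untested is meant among the compounds shown, and "the series" means these compounds.

Compound 2 `C=C1C[C@]23C[C@@]1(O)CC[C@H]2c1ccc(O)c(C)c1[C@@H]3Cn1cc(-c2ccccc2)nn1` carries a hydroxy on its aromatic ring. In a functional assay on SW480 cells (Homo sapiens) for cytotoxicity, read by MTT assay, with a stated time of 4 days (a lower number here means a stronger inhibitor, a higher number a weaker inhibitor), compound 2 gives > 20000 nM, which is a limit of the assay and not a number. Compound 1 `C=C1C[C@]23C[C@@]1(O)CC[C@H]2c1ccc(OS(=O)(=O)c2ccc(C)cc2)c(C)c1[C@@H]3Cn1cc(-c2ccc(Cl)cc2)nn1` differs from compound 2 elsewhere on the shared core and already carries the sulfonyl ester; in this assay compound 1 gives > 20000 nM, again a limit. Both values sit at the limit of > 20000 nM in this assay, at which 2 of the 2 values shown sit, so compound 2 cannot be placed relative to compound 1 beyond that.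

Compound 3 `C=C1C[C@]23C[C@@]1(O)CC[C@H]2c1ccc(OS(=O)(=O)c2ccc(C)cc2)c(C)c1[C@@H]3Cn1cc(-c2ccccc2)nn1` is not yet measured. It differs from compound 2 by (4-methylphenyl)sulfonyl in place of hydrogen on an oxygen on an aromatic ring, the same difference one bond further out reading hydroxy to ((4-methylphenyl)sulfonyl)oxy. Within the data shown here, no measured step covers this change. Since compound 1 with the same sulfonyl ester also sits at the limit of > 20000 nM in this assay, at which 2 of the 2 values shown sit, compound 3 is expected to remain at the limit, the step that the limit leaves unreadable from compound 2 to compound 3 amounting to none beyond the scatter. The estimate for compound 3 is 25000 nM, between 10000 nM and 60000 nM.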

Compound 3, half-maximal inhibitory concentration: > 20000 nM
Compound 3 ended at the assay's limit; the forecaster's own chance of this, stated with the estimate: 80%; the middle value is on the limit's open side.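

No step can be read between compound 3 and compound 2 or compound 1, since in this assay all three compounds give only a limit: the limit of > 20000 nM in this assay, at which 3 of the 3 values shown sit.

The compounds shown leave open whether ((4-methylphenyl)sulfonyl)oxy or hydroxy makes any difference to cytotoxicity, and whether any compound on the shared core gives a value inside the assay's range.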